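Side group swap at the cytotoxicity limit

This account rests on a few compounds, and the source may have more. Where it says the series, first, only, none or still open, it means among the compounds named here.

Measured in an ADME assay on MDBK cells (Bos taurus) for cytotoxicity, read by MTT assay; on this read-out higher numbers stand for lower toxicity in this test and lower numbers for higher toxicity in this test:
- compound 1 `CC1CCC(OCCCCCCN2C[C@H](O)[C@@H](O)[C@H](O)[C@H]2CO)CC1C`: > 500000 nM, a limit
- compound 2 `CC1CCCC(OCCCCCCN2C[C@H](O)[C@@H](O)[C@H](O)[C@H]2CO)C1C`: > 500000 nM, a limit

Compound 2 stands at the limit of > 500000 nM in this assay, at which 2 of the 2 values shown sit. Compound 3 `OC[C@@H]1[C@@H](O)[C@H](O)[C@@H](O)CN1CCCCCCOc1c(F)cc(F)cc1F` differs from it by a group of 9 heavy atoms (6 carbon, 3 fluorine; one six-membered aromatic ring of carbon only) in place of a group of 8 heavy atoms (8 carbon; one six-membered non-aromatic ring of carbon only), on an oxygen on a saturated carbon, bringing in 2,4,6-trifluorophenyl. Within the data shown here, the only measured step that bears on this is a step that the two limits leave unreadable from compound 1 to compound 2, and it offers no size to carry over. No step beyond the scatter is therefore expected in this assay, in either direction. The estimate amounts to a number no higher from compound 2 to compound 3 (the limit leaves the size open), an expected step resting on limits alone. Compound 3 is expected at 500000 nM, with an estimated range of 150000 nM to 1000000 nM.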

Compound 3, half-maximal cytotoxic concentration: > 500000 nM
Compound 3 was reported as a limit (the forecaster's own chance of this, stated with the estimate: 75%); the middle value sits exactly at the limit.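

No step can be read among compound 1, compound 2 and compound 3, since each value is a limit and not a number: the limit of > 500000 nM in this assay, at which 3 of the 3 values shown sit.

The compounds shown leave open whether the 2,4,6-trifluorophenyl group and the two non-aromatic rings differ in cytotoxicity at all.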